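Ring nitrogen swap on the indazole of a diaryl urea

A few compounds are considered here, and "the series" means these few. Any claim that something is new, unique, unknown or untested is made for them only; others in the source may bear on it.

Measured compounds:
compound 1 `O=C(Nc1ccc(-n2ncc3c(Cl)cccc32)cc1)Nc1ccc(Cl)c(C(F)(F)F)c1` gives 3100 nM
compound 2 `O=C(Nc1ccc(-n2ncc3ccccc32)cc1)Nc1ccc(Cl)c(C(F)(F)F)c1` gives 32000 nM

Both were tested in a functional assay on OS-RC-2 cells (Homo sapiens) for cytotoxicity, read by MTT assay, with a stated time of 72 h; on this read-out higher numbers stand for weaker inhibition and lower numbers for stronger inhibition. Compound 2 stands at the highest of the two numbers; its nearest neighbour is compound 1, and the step of a 10-fold higher number from compound 1 to compound 2 (1.01 log units; beyond the scatter) came with hydrogen in place of chloro on an aromatic carbon of the indazole. Compound 3 `O=C(Nc1ccc(-n2ncc3cnccc32)cc1)Nc1ccc(Cl)c(C(F)(F)F)c1` is not yet measured. It differs from compound 2 by a group of 9 heavy atoms (6 carbon, 3 nitrogen; one five-membered aromatic ring with 2 hetero atoms, one six-membered aromatic ring with 1 hetero atom) in place of a group of 9 heavy atoms (7 carbon, 2 nitrogen; one five-membered aromatic ring with 2 hetero atoms, one six-membered aromatic ring of carbon only), on an aromatic carbon. Within the data shown here, no measured step bears on this change directly: the only step in hand concerns a chloro on the six-membered carbon ring of compound 2, not a nitrogen inside that ring. With nothing to guide the direction, compound 3 is expected to stay near compound 2, with a step of a 1.1-fold lower number from compound 2 to compound 3 (0.03 log units; within the scatter) not beyond the scatter. Compound 3 is therefore estimated at 30000 nM, ranging from 10000 nM to 100000 nM.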

Compound 3, half-maximal inhibitory concentration: > 32000 nM
Compound 3: only a limit was reported; the forecaster's own chance of this, stated with the estimate: 20%; middle value at least 1.0-fold (0.02 log units) away from the limit.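

Compound 3 returned only a limit in this assay, not a number: the limit of > 32000 nM in this assay, at which 1 of the 3 values shown sits. The step of a number no lower from compound 2 to compound 3 (the limit leaves the size open) came with a ring nitrogen in the six-membered ring, in a core without chloro, and its size cannot be read. The comparison with the chloro compound can be read, as an at least 10-fold higher number from compound 1 to compound 3 (1.01 log units; beyond the scatter), so the ring nitrogen did not give back what the chloro of compound 1 provides.

The compounds shown leave open how far compound 3 truly lies from compound 2, and whether a ring nitrogen would cost anything in a core that keeps the chloro. They also leave open whether a methoxy or an amine in place of that chloro would match compound 1.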